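A few compounds are considered here, and "the series" means these few. Any claim that something is new, unique, unknown or untested is made for them only; others in the source may bear on it.

In an assay on isolated protein for inhibition of Amine oxidase [flavin-containing] B (Homo sapiens) (a higher number here means a weaker inhibitor, a lower number a stronger inhibitor), compound 2 `CCOc1ccc(C(=O)/C=C/c2ccc(C(F)(F)F)cc2)cc1` gives 210 nM. Its nearest measured neighbour, compound 1 `CCOc1ccc(C(=O)/C=C/c2ccc(Cl)cc2)cc1`, gives 210 nM in this assay, and the step of no change at the digits printed from compound 1 to compound 2 (within the scatter) stayed within the scatter. Compound 3 `CCOc1ccc(C(=O)/C=C/c2ccc([N+](=O)[O-])cc2)cc1` is the next member of the series; the change from compound 2 is nitro in place of trifluoromethyl on an aromatic carbon. Going by the values given here, only the step from compound 1 to compound 2 bears on this change, and it showed no movement beyond the scatter. The step expected in this assay is therefore no change at the digits printed from compound 2 to compound 3 (within the scatter), none beyond the scatter. Compound 3 is estimated at 210 nM in this assay, with a range from 90 nM to 500 nM.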

Compound 3, half-maximal inhibitory concentration: 210 nM
The estimate for compound 3 equals the measured number at the digits printed; measured number inside the range.
By their numbers in this assay, from the lowest: compounds 1, 2 and 3 (each within the scatter of the next).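

In this assay nitro on an aromatic carbon, para to a large group, gives no change at the digits printed from compound 2 to compound 3 (within the scatter) and, set against chloro, no change at the digits printed from compound 1 to compound 3 (within the scatter) at this position. The earlier pair covered only chloro and trifluoromethyl; this position now also takes nitro, which carries hydrogen-bond acceptors where trifluoromethyl has none, and the number holds level across all three groups. Nothing available explains why these groups stand level. On these data alone, whether an amine, a carboxylic acid or plain hydrogen at this position would hold the same level stays open. So does the effect of changing the ethoxy group at the other end of the core.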